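A few compounds are considered here, and "the series" means these few. Any claim that something is new, unique, unknown or untested is made for them only; others in the source may bear on it.

Compound 1 `COc1ccc(N2C(=O)NC3(CSC4=C3C(=O)c3ncccc3C4=O)C2=O)cc1` is the starting point of this comparison. For the measured compounds named here, in a functional assay on HeLa cells (Homo sapiens) for antiproliferative activity, read by MTT assay, with a stated time of 96 h (on this read-out lower numbers stand for stronger inhibition and higher numbers for weaker inhibition), compound 1 gives 1 nM, the lowest of the three numbers measured so far. Its nearest neighbour is compound 2 `O=C1C2=C(C(=O)c3ncccc31)C1(CS2)NC(=O)N(c2ccccc2)C1=O`, which in this assay gives 3 nM; the step between them is a 3.0-fold higher number from compound 1 to compound 2 (0.48 log units; beyond the scatter), a modest loss. Much further away stands compound 3 `Cc1ccc(N2NC(=O)NC3(CSC4=C3C(=O)c3ncccc3C4=O)C2=O)cc1`, which in this assay gives 210 nM; it differs from compound 1 in more than one place, so it serves only as a distant reference.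

Compound 4 `CC(C)(C)c1ccc(N2C(=O)NC3(CSC4=C3C(=O)c3ncccc3C4=O)C2=O)cc1` is the new compound. The change from compound 1 is tert-butyl in place of methoxy on an aromatic carbon. Going by the values given here, the only measured step touching this position is a 3.0-fold higher number from compound 1 to compound 2 (0.48 log units; beyond the scatter), which shows that taking the methoxy group away costs a modest amount. Among the compounds with values here, no measured step shows what a larger group such as tert-butyl does at the same place, so the expectation rests on this single comparison. Compound 4 is expected to sit close to compound 1 or somewhat weaker, with an estimated step of a 4.0-fold higher number from compound 1 to compound 4 (0.60 log units; beyond the scatter). Compound 4 is estimated at 4 nM, with a range from 1 nM to 20 nM.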

Compound 4, half-maximal inhibitory concentration: 100 nM
Beside the measured number, compound 4's estimate is 25-fold (1.40 log units) below it; the measured number lies above the stated range.
By their numbers in this assay, from the lowest: compound 1; then compound 2; then compound 4; then compound 3.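

Replacing methoxy with tert-butyl at this place in this assay gives a 100-fold higher number from compound 1 to compound 4 (2.00 log units; beyond the scatter) and is a large loss, far greater than the modest step seen when hydrogen replaced methoxy. Putting tert-butyl where compound 2 carries hydrogen also gives a 33-fold higher number from compound 2 to compound 4 (1.52 log units; beyond the scatter) as a large step, so among these three compounds the loss comes with the arrival of tert-butyl and not merely with the departure of methoxy. No measurement shown here gives a reason for this loss.

The compounds shown leave open how the number changes for groups at this place that stand between hydrogen and tert-butyl, such as ethyl or isopropyl. They also leave open what a hydroxyl group, an amine or a carboxylic acid would do at the same carbon.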